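A few compounds are considered here, and "the series" means these few. Any claim that something is new, unique, unknown or untested is made for them only; others in the source may bear on it.

Measured in an ADME assay on L6 cells (Rattus norvegicus) for cytotoxicity, with a stated time of 72 h; on this read-out lower numbers stand for stronger inhibition and higher numbers for weaker inhibition:
- Compound 1 `CC(C)(C)C(=O)OC1CC2(N3CCCC3)CC(c3ccccc3)C1C(c1ccccc1)C2`: 7620 nM
- Compound 2 `CC(C)(C)C(=O)OC1CC2(N3CCCCC3)CC(c3ccccc3)C1C(c1ccccc1)C2`: 12000 nM

Compound 1 holds no separate rank on these two numbers. For the measured compounds named here, the only measured step is a 1.6-fold higher number from compound 1 to compound 2 (0.20 log units; within the scatter). That step puts piperidin-1-yl in place of pyrrolidin-1-yl on a saturated ring carbon.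

Compound 3 `O=C(/C=C/c1ccccc1)OC1CC2(N3CCCC3)CC(c3ccccc3)C1C(c1ccccc1)C2` keeps the core of compound 1 but has 2-phenylethenyl in place of tert-butyl on a carbonyl carbon. Going by the values given here, no measured step touches that place, so the data give no direction, and no change beyond the scatter is expected. The estimated step is a 1.3-fold lower number from compound 1 to compound 3 (0.10 log units; within the scatter). For compound 3 the expected value is 6000 nM, with an estimated range of 2000 nM to 18000 nM.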

Compound 3, half-maximal inhibitory concentration: 3500 nM
Beside the measured number, compound 3's estimate is 1.7-fold (0.23 log units) above it; low and high end bracket the measured number.
By their numbers in this assay, from the lowest: compound 3; then compounds 1 and 2 (each within the scatter of the next).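

In this assay, the group on the carbonyl carbon can shift the number: 2-phenylethenyl in place of tert-butyl gives a 2.2-fold lower number from compound 1 to compound 3 (0.34 log units; beyond the scatter). This modest step is the only one shown beyond the scatter, whereas the swap of pyrrolidin-1-yl for piperidin-1-yl stayed within it. No evidence is available that explains this difference.

From the compounds shown here alone, it remains open whether the double bond matters, which 2-phenylethyl on the same carbonyl carbon could test, or whether phenyl alone would do the same. Going by these compounds, the effect of this change with piperidin-1-yl in the molecule also remains open.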